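This account rests on a few compounds, and the source may have more. Where it says the series, first, only, none or still open, it means among the compounds named here.

In an ADME assay on MT4 cells (Homo sapiens) for cytotoxicity, read by MTT assay, with a stated time of 5 days (a higher number here means that more compound is tolerated, a lower number that less compound is tolerated), compound 1 `Cc1cc(-c2ccc(C#N)cc2)ccc1[C@H](O)c1ccnc(Nc2ccc(C#N)cc2)n1` gives 4000 nM, the lower of the two numbers available. Its stereoisomer, compound 2 `Cc1cc(-c2ccc(C#N)cc2)ccc1[C@@H](O)c1ccnc(Nc2ccc(C#N)cc2)n1`, gives 35600 nM. The step of an 8.9-fold higher number from compound 1 to compound 2 (0.95 log units; beyond the scatter) lies beyond the scatter and is tied to the fact that compounds 1 and 2 differ only in the configuration as drawn.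

Compound 3 `Cc1cc(-c2ccc(C#N)cc2)cc(C)c1[C@H](O)c1ccnc(Nc2ccc(C#N)cc2)n1` shares the core of compound 1 and has its stereocentre drawn the same way, but it carries one structural change: methyl in place of hydrogen on an aromatic carbon. This is methyl in place of hydrogen on an aromatic carbon, ortho to a large group and meta to a 4-cyanophenyl group.

Among the compounds with values here, no measured step covers such a change. The only one, an 8.9-fold higher number from compound 1 to compound 2 (0.95 log units; beyond the scatter), concerns configuration alone, so it gives no direction for a new methyl and shows only that this series can move in this assay. No step beyond the scatter is therefore expected, although the range is kept wide. The expected change is a 1.1-fold higher number from compound 1 to compound 3 (0.05 log units; within the scatter). For compound 3, the estimated value is 4500 nM, with an expected range from 1500 nM to 18000 nM.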

Compound 3, half-maximal cytotoxic concentration: 5560 nM
Beside the measured number, compound 3's estimate is 1.2-fold (0.09 log units) below it; the range from low to high includes it.
By their numbers in this assay, from the lowest: compounds 1 and 3 (each within the scatter of the next); then compound 2.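

In this assay, methyl in place of hydrogen on this aromatic carbon, ortho to a large group and meta to a 4-cyanophenyl group, gives a 1.4-fold higher number from compound 1 to compound 3 (0.14 log units; within the scatter), so this position carries the added methyl without a step beyond the scatter. The earlier pair spoke only to configuration, through an 8.9-fold higher number from compound 1 to compound 2 (0.95 log units; beyond the scatter), whereas this new pair is the first shown to speak to a substituent on this ring, and here the two compounds cannot be told apart in this read-out. The information at hand concerns only configuration and offers no explanation for the result with the new methyl.

The compounds shown leave open whether a larger group on this same carbon, such as an ethyl, a methoxy or an amine, would also stay within the scatter, since methyl is the only replacement for hydrogen shown here. They also leave open whether the stereocentre drawn R would, with this added methyl present, again give a number beyond the scatter from the S form.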